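The source may report more compounds than this note shows. Statements on the series, on what has been measured and on what is new or still open speak of the compounds shown alone.

Of the compounds shown here, three have been tested so far in an ADME assay on MT4 cells (Homo sapiens) for activation, read by MTT assay; a higher number here means that more compound is tolerated, a lower number that less compound is tolerated. Among the measured compounds shown here, compound 1 `CCc1c(C(C)c2c(F)cccc2Cl)nc(SC(C)CC)[nH]c1=O` is the first of them. In this assay compound 1 gives > 3000 nM, which is a limit of the assay rather than a number. Compound 3 `CCc1c(C(C)c2c(F)cccc2F)nc(SC(C)CC)[nH]c1=O` differs from compound 1 by fluoro in place of chloro on an aromatic carbon. In this assay compound 3 gives > 3000 nM, again a limit. The step that the two limits leave unreadable from compound 1 to compound 3 therefore cannot be read, because of the limit of > 3000 nM in this assay, at which 3 of the 3 values shown sit. Compound 2 `CCC(c1nc(SC(C)C)[nH]c(=O)c1C)c1c(F)cccc1Cl` has a different core; the difference between the two cores is not broken down here. In this assay compound 2 gives > 3000 nM, also a limit. Compound 4 `CCC(c1nc(SC(C)C)[nH]c(=O)c1C)c1c(F)cccc1F` has not yet been measured; it differs from compound 2 by fluoro in place of chloro on an aromatic carbon, the same change as from compound 1 to compound 3. For the measured compounds named here, since every value so far sits at the limit, as the limit of > 3000 nM in this assay, at which 3 of the 3 values shown sit, shows, compound 4 is expected to behave alike. The step expected in this assay is a step that the limit leaves unreadable from compound 2 to compound 4. For compound 4 the estimate is 5000 nM, between 3000 nM and 20000 nM.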

Compound 4, half-maximal cytotoxic concentration: > 30000 nM
Compound 4 gave a limit, no number; the forecaster's own chance of this, stated with the estimate: 85%; middle value at least 6.0-fold (0.77 log units) from the limit.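

In this assay compound 4 gives > 30000 nM, which is a limit and not a number. Compound 2 also gives only a limit, so no step can be read between compound 2 and compound 4. The compounds shown leave open what concentration any of them reaches in this assay, and whether fluoro in place of chloro changes it.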